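The source may report more compounds than this note shows. Statements on the series, on what has been measured and on what is new or still open speak of the compounds shown alone.

Measured so far: compound 1 `C=CCn1c(=O)/c(=C\c2cccc(F)c2)[nH]c(=O)/c1=C\c1ccccc1OC` with 9100 nM, and compound 2 `C=CCn1c(=O)/c(=C\c2cc(F)ccc2C)[nH]c(=O)/c1=C\c1ccccc1OC` with 2900 nM.

Both compounds share the same core and differ only in one aromatic ring. For the measured compounds named here, in a functional assay on HeLa cells (Homo sapiens) for cytotoxicity, read by CCK-8 assay, with a stated time of 72 h (a lower number here means a stronger inhibitor, a higher number a weaker inhibitor), compound 2 gives 2900 nM, the lowest of the two numbers, and the only measured step, a 3.1-fold lower number from compound 1 to compound 2 (0.50 log units; beyond the scatter), came from a methyl in place of hydrogen on an aromatic carbon.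

Compound 3 `C=CCn1c(=O)/c(=C\c2ccc(F)c(Br)c2)[nH]c(=O)/c1=C\c1ccccc1OC` is not yet measured. It changes compound 2 as follows: 3-bromo-4-fluorophenyl in place of 5-fluoro-2-methylphenyl on a double-bonded chain carbon bound to an aromatic carbon. The methyl that marked the step from compound 1 to compound 2 is gone, and a bromine enters while the fluorine moves. Going by the values given here, no measured step covers a bromine or this fluorine placement, so only the methyl step offers guidance. The loss of the methyl suggests a number somewhat higher than that of compound 2, possibly near that of compound 1.

Compound 3 is therefore expected to give about 5500 nM in this assay, within a range of 2000 nM to 15000 nM, a step of a 1.9-fold higher number from compound 2 to compound 3 (0.28 log units; within the scatter).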

Compound 3, half-maximal inhibitory concentration: "not active" (no number reported)
For compound 3 the study gives words and no number; there is nothing to compare the estimate with.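

Compound 3 is reported in words only in this assay, so no new step can be read between it and compound 2 or compound 1. Nothing shown explains this result. The compounds shown leave open how 3-bromo-4-fluorophenyl alone, or either of its two halogens, affects this read-out.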